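Replacing 4-methoxyphenyl with 2,4-dihydroxyphenyl in an antiproliferative series

This account rests on a few compounds, and the source may have more. Where it says the series, first, only, none or still open, it means among the compounds named here.

Values in a functional assay on A549 cells (Homo sapiens) for antiproliferative activity, read by MTT assay, with a stated time of 72 h (a lower number here means a stronger inhibitor, a higher number a weaker inhibitor), so far:
- compound 1 `O=C(N/N=C/c1ccccc1)Nc1ccc(Oc2ccnc3[nH]ccc23)c(F)c1` gives 2500 nM
- compound 2 `O=C(N/N=C/c1ccc(F)cc1Cl)Nc1ccc(Oc2ccnc3[nH]ccc23)c(F)c1` gives 10 nM
- compound 3 `COc1ccc(/C=N/NC(=O)Nc2ccc(Oc3ccnc4[nH]ccc34)c(F)c2)cc1` gives 3980 nM

Compound 3 and compound 1 together form the high end of these numbers, separated only by a 1.6-fold higher number from compound 1 to compound 3 (0.20 log units; within the scatter), while a 400-fold higher number from compound 2 to compound 3 (2.60 log units; beyond the scatter) sets compound 3 far from compound 2. Compound 4 `O=C(N/N=C/c1ccc(O)cc1O)Nc1ccc(Oc2ccnc3[nH]ccc23)c(F)c1` has not yet been measured. It carries 2,4-dihydroxyphenyl in place of 4-methoxyphenyl on a carbon with a double bond to nitrogen. Two measured steps alter the group at this place: a 250-fold lower number from compound 1 to compound 2 (2.40 log units; beyond the scatter) is large, whereas a 1.6-fold higher number from compound 1 to compound 3 (0.20 log units; within the scatter) is not. Neither introduces a hydroxy group, so the data cannot settle which kind of step this will be. Since only compound 2 has moved far, the expected result in this assay is a 1.6-fold lower number from compound 3 to compound 4 (0.20 log units; within the scatter), with no shift beyond the scatter, although a large drop remains possible. The estimate for compound 4 is 2500 nM, with an expected range from 300 nM to 10000 nM.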

Compound 4, half-maximal inhibitory concentration: 5840 nM
Estimate against measurement, compound 4: 2.3-fold (0.37 log units) below; measured number inside the range.
By their numbers in this assay, from the lowest: compound 2; then compounds 1, 3 and 4 (each within the scatter of the next, the first and the last beyond it).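

In this assay, 2,4-dihydroxyphenyl brings hydrogen-bond donors that 4-methoxyphenyl lacks, yet a 1.5-fold higher number from compound 3 to compound 4 (0.17 log units; within the scatter) is no shift beyond the scatter, so adding these donors at this position does not move the series towards compound 2. The distance to the 2-chloro-4-fluorophenyl group stays large, with a 580-fold higher number from compound 2 to compound 4 (2.77 log units; beyond the scatter) as the step from that group, while a 2.3-fold higher number from compound 1 to compound 4 (0.37 log units; beyond the scatter) is a modest step from plain phenyl, leaving 2-chloro-4-fluorophenyl as the only group shown that stands far apart. Nothing measured here accounts for this result.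

The compounds shown do not separate the chloro group from the fluoro group in the potency of compound 2. They also leave open how a ring carrying a single chloro group, a single fluoro group, an amine or a carboxylic acid would read here.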